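The compounds below may be only part of what the source reports. "The series", "measured", "known", "first", "only" and "open" are said of these compounds alone.

Measured compounds and their values in an ADME assay on microsomes from liver (Rattus norvegicus, strain Sprague-Dawley) for metabolic stability, read by HPLC, using NADPH, with stated times of 5 min and 60 min, tested at 10 uM; on this read-out lower numbers stand for a shorter-lived compound and higher numbers for a longer-lived compound:

Compound 1, `CC(C)S(=O)(=O)Nc1ccc(CNC(=O)c2ccc(C(C)(C)C)cc2)c(Cl)c1`: 0.983 h
Compound 2, `CS(=O)(=O)Nc1ccc(CNC(=O)c2ccc(C34CC(C3)C4)cc2)c(Cl)c1`: 1.35 h

Of the compounds shown here, two sharing one core have been measured in this assay. Compound 1 gives 0.983 h, and compound 2 gives 1.35 h. Compound 2 stands with the higher of the two numbers, but its nearest neighbour, compound 1, lies within the usual scatter of it, so the two values cannot be told apart on this read-out.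

The next compound, compound 3, `CC(C)Oc1ccc(C(=O)NCc2ccc(NS(C)(=O)=O)cc2Cl)cc1`, has not yet been measured in this assay. It follows from compound 2 by the change (a group of 4 heavy atoms (3 carbon, 1 oxygen; no ring) in place of a group of 5 heavy atoms (5 carbon; 2 four-membered non-aromatic rings of carbon only), on an aromatic carbon), on an aromatic carbon of a six-membered aromatic ring of carbon only, para to a large group. Going by the values given here, no measured pair of compounds in this set differs in one place alone, so there is no measured step to rest on. The only gap shown, between compound 1 and compound 2, does not exceed the scatter. A step from compound 2 to compound 3 of a 1.4-fold lower number from compound 2 to compound 3 (0.13 log units; within the scatter) is therefore expected, at most modest and close to no change beyond the scatter. For compound 3 the estimated half-life in this assay is 1 h, with a range from 0.45 h to 2.3 h.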

Compound 3, half-life: 1.85 h
Beside the measured number, compound 3's estimate is 1.9-fold (0.27 log units) below it; the measured number falls inside the stated range.
By their numbers in this assay, from the lowest: compounds 1, 2 and 3 (each within the scatter of the next).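

In this assay the set now holds its first comparison of compounds that differ in one place, and it gives a 1.4-fold higher number from compound 2 to compound 3 (0.14 log units; within the scatter), a step that stays within the usual scatter. On this aromatic carbon, para to a large group, isopropoxy in place of the group with 2 four-membered non-aromatic rings removes both rings and brings in an oxygen and a hydrogen-bond acceptor, yet the half-life read-out does not separate the two compounds, so this one change, large as it is in what is counted, shows no effect that can be told from the scatter. Nothing measured here speaks to why the two compounds read alike.

The compounds shown leave open whether any group on this aromatic carbon can move the half-life beyond the scatter, for instance an amine, a carboxylic acid or a longer chain. From the compounds shown here alone, they also offer no comparison in one place for the rest of the shared core, so how much the half-life depends on the other parts of the molecule remains unknown.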